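The source may hold more compounds than are shown below. What is called first, only, known or untested is meant among the compounds shown, and "the series" means these compounds.

Working notes on the series. Among the compounds with values here, compound 1 `COc1nc(N)nc2c1c(-c1cc3ccccc3o1)cn2[C@@H]1O[C@H](CO)[C@@H](O)[C@H]1O` is the only measured member that gives a number in a functional assay on CEM-DNR-bulk cells (Homo sapiens), read by MTT assay, with a stated time of 72 h; a higher number here means a weaker inhibitor, a lower number a stronger inhibitor: compound 1 gives 16700 nM. Compound 2 `COc1nc(N)nc2c1c(-c1ccccc1)cn2[C@@H]1O[C@H](CO)[C@@H](O)[C@H]1O` returns only a limit in this assay, > 20000 nM. Compound 3 `Nc1nc(N)c2c(-c3ccccc3)cn([C@@H]3O[C@H](CO)[C@@H](O)[C@H]3O)c2n1`, with amino in place of methoxy on an aromatic carbon, likewise returns only a limit, > 20000 nM. Two of the three values therefore sit at the same limit (the limit of > 20000 nM in this assay, at which 2 of the 3 values shown sit), and compound 2 stands at the weak end of what the numbers can show, with no value of its own.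

Compound 4 `C#Cc1cn([C@@H]2O[C@H](CO)[C@@H](O)[C@H]2O)c2nc(N)nc(OC)c12` differs from compound 2 by ethynyl in place of phenyl on an aromatic carbon.

Of the measured steps, an at least 1.1-fold higher number from compound 1 to compound 2 (0.07 log units; that floor lies within the scatter) is the one that touches this aromatic carbon; its floor lies within the scatter, so it says little about direction. The step that the two limits leave unreadable from compound 2 to compound 3 concerns another position and is unreadable. Within the data shown here, no measured step covers ethynyl at all.

Compound 4 is expected at 25000 nM, within 8000 nM to 80000 nM. The expected step is a step that the limit leaves unreadable from compound 2 to compound 4, most likely reported again only as a limit.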

Compound 4, half-maximal inhibitory concentration: > 20000 nM
Compound 4: no number, only a limit; the forecaster's own chance of this, stated with the estimate: 75%; the middle value does not contradict the limit.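

Putting ethynyl, a group with no ring, on this aromatic carbon does not bring out a number in this assay: compound 4, like compound 2, gives only a limit, and the steps that join two limits cannot be read. Within the data shown here, the one readable step is an at least 1.1-fold higher number from compound 1 to compound 4 (0.07 log units; that floor lies within the scatter), and it fixes no direction for the exchange of 1-benzofuran-2-yl for ethynyl. Small ethynyl and larger phenyl thus give the same limit, and the series now gathers there: the limit of > 20000 nM in this assay, at which 3 of the 4 values shown sit.

Still open, from the compounds shown here alone, is whether an amine, a carboxylic acid or a chain longer than ethynyl on this aromatic carbon would give a number in this assay that stands clear of the scatter from compound 1. Also open, going by these compounds, is whether compound 2, compound 3 and compound 4 differ from one another at all.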